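The source may report more compounds than this note shows. Statements on the series, on what has been measured and on what is new or still open speak of the compounds shown alone.

In a functional assay on the whole organism (aorta) with Rattus norvegicus as the target (a higher number here means a larger maximal response, a lower number a smaller maximal response), compound 1 `CC1(C)C=C(/C(S)=N\CCC#N)c2cc([N+](=O)[O-])ccc2O1` gives 78.5%. Compound 2 `CC1(CF)C=C(/C(S)=N\CCC#N)c2cc([N+](=O)[O-])ccc2O1` carries one change relative to compound 1, namely (fluoro in place of hydrogen on a saturated chain carbon bound to a saturated ring carbon), and in this assay compound 2 gives 59.6%, so that a number 18.9 percentage points lower from compound 1 to compound 2 (beyond the scatter). Compound 3 `CC1(CF)C=C(C(=O)NCCC#N)c2cc([N+](=O)[O-])ccc2O1` gives 71%, and a number 11.4 percentage points higher from compound 2 to compound 3 (beyond the scatter); how the core of compound 3 differs from the core of compound 1 is not broken down here. Compound 4 `N#CCCNC(=O)C1=CC(CF)(CF)Oc2ccc([N+](=O)[O-])cc21` applies to compound 3 the same change already seen once: fluoro in place of hydrogen on a saturated chain carbon bound to a saturated ring carbon. Since the earlier step of a number 18.9 percentage points lower from compound 1 to compound 2 (beyond the scatter) lowered the maximal response when this change was made once, a step of similar direction and size is expected the second time, a number 16 percentage points lower from compound 3 to compound 4 (beyond the scatter). Compound 4 is therefore estimated at 55%, most likely between 40% and 70%.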

Compound 4, intrinsic activity: the largest response reached, in percent of the reference agonist's: 72.3%
The estimate for compound 4 lay 17.3 percentage points below the measured number; measured number outside the range, above it.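

In this assay, replacing methyl with fluoromethyl once more gave a number 1.3 percentage points higher from compound 3 to compound 4 (within the scatter), so the loss of maximal response seen on the first core did not recur. The effect of this change therefore did not carry from one core to the other in this series: the same change on two cores in this assay, a number 18.9 percentage points lower (beyond the scatter) from compound 1 to compound 2 and a number 1.3 percentage points higher (within the scatter) from compound 3 to compound 4, 20.2 percentage points apart, beyond the scatter of two such steps
This does not show which difference between the cores matters, the sulfur-bearing or oxygen-bearing group or the fluoromethyl already present in compound 3, as each step rests on a single pair of compounds.

The compounds shown leave open how the maximal response would move with another group in place of fluoromethyl, such as hydroxymethyl or aminomethyl. They also leave open the effect of replacing the nitrile with a carboxylic acid.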